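From 4-cyanophenyl to cyclohexyl on the shared core

The source may report more compounds than this note shows. Statements on the series, on what has been measured and on what is new or still open speak of the compounds shown alone.

Compound 1 `CCCOc1ccc(C(O)C2OC(=O)c3c(OC)cc(OC)cc32)cc1`: 9260 nM
Compound 2 `COc1cc(OC)c2c(c1)C(C(O)c1ccc(OCc3ccccc3)cc1)OC2=O`: > 10000 nM, a limit
Compound 3 `COc1cc(OC)c2c(c1)C(C(O)c1ccc(OCc3ccc(C#N)cc3)cc1)OC2=O`: 7360 nM

In a functional assay on RAW264.7 cells (Mus musculus) for inhibition, read by Griess assay, with stated times of 1 h and 24 h (a lower number here means a stronger inhibitor, a higher number a weaker inhibitor), compound 3 gives 7360 nM. The step of a 1.3-fold lower number from compound 1 to compound 3 (0.10 log units; within the scatter) lies within the scatter, so compound 3 cannot be ranked against compound 1. For compound 2 the assay reports only a limit, > 10000 nM.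

Compound 4 `COc1cc(OC)c2c(c1)C(C(O)c1ccc(OCC3CCCCC3)cc1)OC2=O` has not yet been measured. It differs from compound 3 by cyclohexyl in place of 4-cyanophenyl on a saturated chain carbon bound to an oxygen on an aromatic ring, with cyclohexyl in place of 4-cyanophenyl on a saturated chain carbon bound to an oxygen on an aromatic ring.

Within the data shown here, three measured steps bear on this change. They are an at least 1.0-fold higher number from compound 1 to compound 2 (0.03 log units; that floor lies within the scatter), a 1.3-fold lower number from compound 1 to compound 3 (0.10 log units; within the scatter) and an at least 1.3-fold lower number from compound 2 to compound 3 (0.13 log units; that floor lies within the scatter), and none goes beyond the scatter, though the two involving compound 2 are only floors. A clear shift is therefore not expected, and a reading at the limit remains possible. The expected step is a 1.3-fold higher number from compound 3 to compound 4 (0.11 log units; within the scatter), which is not expected to exceed the scatter.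

Compound 4 is expected at 9500 nM, with an estimated range from 5000 nM to 18000 nM.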

Compound 4, half-maximal inhibitory concentration: > 10000 nM
Compound 4: only a limit was reported (the forecaster's own chance of this, stated with the estimate: 40%); middle value at least 1.0-fold (0.02 log units) away from the limit.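

In this assay compound 4 gives only a limit, > 10000 nM. Replacing 4-cyanophenyl with cyclohexyl on a saturated chain carbon bound to an oxygen on an aromatic ring gives an at least 1.3-fold higher number from compound 3 to compound 4 (0.13 log units; that floor lies within the scatter), and the comparison with the ethyl group gives an at least 1.0-fold higher number from compound 1 to compound 4 (0.03 log units; that floor lies within the scatter), so these floors rank compound 4 against neither compound 3 nor compound 1. The step between the phenyl of compound 2 and the cyclohexyl of compound 4 cannot be read, since both compounds sit at the same limit: the limit of > 10000 nM in this assay, at which 2 of the 4 values shown sit.

Going by these compounds, how far compound 2 and compound 4 lie past that limit remains open. Also open, on these data alone, is whether an amine or a carboxylic acid in place of cyclohexyl would move the number beyond the scatter.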